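The source may hold more compounds than are shown below. What is called first, only, known or untested is meant among the compounds shown, and "the series" means these compounds.

Measured in a functional assay on COLO 205 cells (Homo sapiens) for inhibition, read by sulforhodamine B assay; on this read-out higher numbers stand for weaker inhibition of growth and lower numbers for stronger inhibition of growth
- compound 1 `c1ccc(-c2ccc(-c3ccc(-c4nc5ccccc5[nH]4)cc3)cc2)cc1` gives 100000 nM
- compound 2 `Cc1ccc2[nH]c(-c3ccc(-c4ccc(-c5ccc(N(C)C)cc5)cc4)cc3)nc2c1` gives 9210 nM
- compound 3 `COc1ccc(-c2ccc(-c3ccc(-c4nc5cc(C)ccc5[nH]4)cc3)cc2)cc1OC` gives 2320 nM

Compound 1 stands highest of the three numbers, beyond the scatter from both others. Compound 4 `FC(F)(F)c1ccc(-c2ccc(-c3ccc(-c4nc5ccccc5[nH]4)cc3)cc2)cc1` differs from it by trifluoromethyl in place of hydrogen on an aromatic carbon (trifluoromethyl in place of hydrogen on an aromatic carbon, para to a large group). Among the compounds with values here, no measured step starts from compound 1. Within the data shown here, the one measured step, a 4.0-fold lower number from compound 2 to compound 3 (0.60 log units; beyond the scatter) and modest, exchanges one substituent for another on an aromatic carbon, so it bears only loosely on this change. A modest fall in the number is therefore expected, though a value near that of compound 1 remains possible. The expected change is a 6.7-fold lower number from compound 1 to compound 4 (0.82 log units; beyond the scatter) in this assay and it is uncertain. For compound 4 the estimated value is 15000 nM with an expected range of 3000 nM to 100000 nM on this read-out.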

Compound 4, concentration for 50% growth inhibition: 33900 nM
Beside the measured number, compound 4's estimate is 2.3-fold (0.35 log units) below it; the range from low to high includes it.
By their numbers in this assay, from the lowest: compound 3; then compound 2; then compound 4; then compound 1.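

In this assay, phenyl to 4-(trifluoromethyl)phenyl gives a 2.9-fold lower number from compound 1 to compound 4 (0.47 log units; beyond the scatter) on the core of compound 1. Within the data shown here, this is the first step read at this aromatic carbon, para to a large group, and it shows that the number responds to a change at this position. Nothing measured here accounts for the step.

As far as these compounds go, whether this response is specific to trifluoromethyl stays open, as a single substituent cannot separate it from a fluorine atom, a nitrile or a carboxylic acid at this position. From the compounds shown here alone, whether the step carries over to the methyl-bearing core of compound 2 and compound 3 also stays open.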